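The source may report more compounds than this note shows. Statements on the series, on what has been measured and on what is new or still open speak of the compounds shown alone.

Compound 1 `C[C@@]1(c2nc(NC(=O)c3ncc(C#N)cc3N)ccc2F)CO[C@@](C)(C(F)(F)F)C(N)=N1`: 13 ug/mL
Compound 2 `C[C@@]1(c2nc(NC(=O)c3ncc(OC(F)F)cc3Cl)ccc2F)CO[C@@](C)(C(F)(F)F)C(N)=N1`: 13 ug/mL

In a physicochemical assay for solubility, at pH 6.8 (on this read-out lower numbers stand for lower solubility and higher numbers for higher solubility), compound 2 gives 13 ug/mL, level with compound 1 at 13 ug/mL. The next compound to be read is compound 3 `C[C@@]1(c2nc(NC(=O)c3ncc(C(F)(F)F)cc3N)ccc2F)CO[C@@](C)(C(F)(F)F)C(N)=N1`. It differs from compound 2 as follows: a group of 11 heavy atoms (6 carbon, 2 nitrogen, 3 fluorine; one six-membered aromatic ring with 1 hetero atom) in place of a group of 11 heavy atoms (6 carbon, 1 nitrogen, 1 oxygen, 2 fluorine, 1 chlorine; one six-membered aromatic ring with 1 hetero atom), on a carbonyl carbon. The exchange lies on a carbonyl carbon whose other neighbours are: amide-type nitrogen. Going by the values given here, one measured step bears on it, and it concerns a group on a carbonyl carbon too: no change at the digits printed from compound 1 to compound 2 (within the scatter). That is a single step, so the ground for a forecast is thin, but it gives no reason to expect a move in either direction in this assay. The change expected is no change at the digits printed from compound 2 to compound 3 (within the scatter), with nothing expected beyond the scatter. For compound 3 the estimated value is 13 ug/mL, with an expected range from 6 ug/mL to 28 ug/mL.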

Compound 3, solubility: 13 ug/mL
Compound 3: middle estimate and measured number agree at the digits printed, and the stated range covers the measured number.
By their numbers in this assay, from the lowest: compounds 1, 2 and 3 (each within the scatter of the next).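

In this assay, a second exchange of the group on the carbonyl carbon shows no change at the digits printed from compound 2 to compound 3 (within the scatter), so the three groups seen at this place all sit within the scatter of one another. The new pair also narrows the change to one substituent, which the step between compound 1 and compound 2 could not do: trifluoromethyl in place of cyano on an aromatic carbon shows no change at the digits printed from compound 1 to compound 3 (within the scatter). No measurement is available that accounts for this flat read-out.

The compounds shown leave open whether an amine or a carboxylic acid in place of trifluoromethyl on that aromatic carbon would move the read-out beyond the scatter. They also leave open whether exchanges elsewhere on the shared core would do so.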